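Replacing the benzylamino linker of compound 2 with phenoxy

The source may hold more compounds than are shown below. What is called first, only, known or untested is meant among the compounds shown, and "the series" means these compounds.

Measured compounds:
compound 1, `Nc1cc(N)c2nc(-c3ccccc3)c(NCc3ccc(Cl)c(Cl)c3)nc2c1`: 45700 nM
compound 2, `Nc1cc(N)c2nc(-c3ccccc3)c(NCc3ccc(F)cc3)nc2c1`: 5750 nM
compound 3, `COc1ccc(CNc2nc3cc(N)cc(N)c3nc2-c2ccccc2)cc1`: 83200 nM

Three compounds sharing one core were tested in a functional assay on NCI/ADR-RES cells (Homo sapiens) for inhibition, read by sulforhodamine B assay, with a stated time of 48 h; on this read-out higher numbers stand for weaker inhibition of growth and lower numbers for stronger inhibition of growth. Compound 2 gives the lowest number of the three: there is a 7.9-fold lower number from compound 1 to compound 2 (0.90 log units; beyond the scatter), and then a 14-fold higher number from compound 2 to compound 3 (1.16 log units; beyond the scatter) further still, both steps beyond the scatter. Between compound 1 and compound 3 the step is a 1.8-fold higher number from compound 1 to compound 3 (0.26 log units; within the scatter), within the scatter. All three measured steps concern only the substituent on the benzyl ring; the linker between the core and that ring is the same throughout.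

Compound 4, `Nc1cc(N)c2nc(-c3ccccc3)c(Oc3ccc(F)cc3)nc2c1`, changes that linker instead: 4-fluorophenoxy in place of (4-fluorobenzyl)amino on an aromatic carbon. Going by the values given here, no measured step touches this position, so the measured steps give no direct guide. With nothing to anchor a direction, the expectation for compound 4 is a number near that of compound 2, with a wide range, and a step of a 1.6-fold higher number from compound 2 to compound 4 (0.19 log units; within the scatter) that may fall within the scatter. Compound 4 is thus estimated at 9000 nM, between 2500 nM and 40000 nM.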

Compound 4, concentration for total growth inhibition: 36300 nM
Estimate against measurement, compound 4: 4.0-fold (0.61 log units) below; low and high end bracket the measured number.
By their numbers in this assay, from the lowest: compound 2; then compounds 4, 1 and 3 (each within the scatter of the next, the first and the last beyond it).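

Going by these compounds alone, the linker position turns out to matter in its own right: in this assay, the step of a 6.3-fold higher number from compound 2 to compound 4 (0.80 log units; beyond the scatter) shows that the number moves beyond the scatter even though the 4-fluoro-substituted ring stays in place, whereas the earlier steps changed only the substituent on that ring. The change is nevertheless a composite one, since 4-fluorophenoxy brings 8 heavy atoms and 0 hydrogen-bond donors where (4-fluorobenzyl)amino had 9 heavy atoms and 1 hydrogen-bond donor, so this single step cannot assign the shift to the oxygen or to the shorter link alone. Nothing measured here accounts for the shift in this number.

The compounds shown leave open which part of the linker carries the effect, a question that a 4-fluoroanilino group, which keeps the nitrogen without the chain carbon, and a 4-fluorobenzyloxy group, which keeps the chain carbon with an oxygen in place of the nitrogen, would help to separate. They also leave open whether a longer chain such as 2-(4-fluorophenyl)ethylamino would be tolerated, and whether the phenoxy linker would give a similar step with the 4-methoxyphenyl or 3,4-dichlorophenyl rings.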